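Leucine benzyl ester in place of methionine benzyl ester

This account rests on a few compounds, and the source may have more. Where it says the series, first, only, none or still open, it means among the compounds named here.

Compound 1 `CSCC[C@H](NC(=O)CN(c1nc(Cl)nc2[nH]cnc12)C1CC1)C(=O)OCc1ccccc1` gives 31.6% in a functional assay on the whole organism (Tail, strain ICR) with Mus musculus as the target, in the tail flick test, with a stated time of 120 min, at a dose of 25 umol/kg by the oral route; a lower number here means a weaker effect, a higher number a stronger effect of the compound at the dose given. Compound 2 `C[C@@H](O)[C@H](NC(=O)CN(c1nc(Cl)nc2[nH]cnc12)C1CC1)C(=O)O` gives 37.6% in this assay, and compound 3 `C[C@H](NC(=O)CN(c1nc(Cl)nc2[nH]cnc12)C1CC1)C(=O)O` gives 28.4%; all three numbers lie within the scatter of one another, so compound 1 sits among them with no separation. Compound 4 `CC(C)C[C@H](NC(=O)CN(c1nc(Cl)nc2[nH]cnc12)C1CC1)C(=O)OCc1ccccc1` differs from compound 1 by isopropyl in place of (methylsulfanyl)methyl on a saturated chain carbon, two bonds along the chain from an amide-type nitrogen and a carbonyl carbon. Going by the values given here, no measured step exchanges one side chain for another at this place; the only step touching the side chain, a number 9.2 percentage points lower from compound 2 to compound 3 (within the scatter), is within the scatter. With nothing pointing in either direction, the estimated step of a number 0.4 percentage points higher from compound 1 to compound 4 (within the scatter) is expected to stay within the scatter. Compound 4 is therefore estimated at 32%, with a range from 20% to 44%.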

Compound 4, a percentage reported as activity, at one dose (the size of the read-out at that dose, not a potency): 8.58%
Compound 4: the middle estimate sits 23.4 percentage points above what was measured, outside the stated range (below it).
By their numbers in this assay, from the lowest: compound 4; then compounds 3, 1 and 2 (each within the scatter of the next).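

In this assay, going by these compounds alone, this position is sensitive to the change: a number 23 percentage points lower from compound 1 to compound 4 (beyond the scatter), the only step beyond the scatter, while the side-chain step a number 9.2 percentage points lower from compound 2 to compound 3 (within the scatter) is not. The leaving and entering groups have the same count of heavy atoms, so that count does not separate them; they differ in the sulfur and the branching. No measurement shown gives a reason for this step.

As far as these compounds go, whether the sulfur or the branching carries the step stays open, and a straight butyl chain at this place would help separate them. Also open, from the compounds shown here alone, is whether the step holds with a carboxylic acid in place of the benzyl ester.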